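A few compounds are considered here, and "the series" means these few. Any claim that something is new, unique, unknown or untested is made for them only; others in the source may bear on it.

Measured compounds:
compound 1 `COc1cc2c(Oc3ccc(NC(=O)N/N=C/c4ccc(C(F)(F)F)cc4)cc3F)ccnc2cc1OCCCN1CCCCC1`: in a functional assay on A549 cells (Homo sapiens) for cytotoxicity, read by MTT assay, with a stated time of 72 h (on this read-out higher numbers stand for weaker inhibition and lower numbers for stronger inhibition), compound 1 gives 660 nM.
compound 2 `COc1cc2c(Oc3ccc(NC(=O)N/N=C/c4ccc(OC(F)(F)F)cc4)cc3F)ccnc2cc1OCCCN1CCCCC1`: compound 2 gives 590 nM.
compound 3 `COc1cc2c(Oc3ccc(NC(=O)N/N=C/c4ccc(O)cc4)cc3F)ccnc2cc1OCCCN1CCCCC1`: compound 3 gives 780 nM.

Compound 3 holds the highest of the three numbers, but both of its steps stay within the scatter: a 1.2-fold higher number from compound 1 to compound 3 (0.07 log units; within the scatter) and a 1.3-fold higher number from compound 2 to compound 3 (0.12 log units; within the scatter). Compound 1 and compound 2 are likewise within the scatter of each other, a 1.1-fold lower number from compound 1 to compound 2 (0.05 log units; within the scatter). The three values thus read as a single level; no ordering among them is supported.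

Compound 4 `COc1cc2c(Oc3ccc(NC(=O)N/N=C/c4ccncc4)cc3F)ccnc2cc1OCCCN1CCCCC1` has not yet been measured. Against compound 3 it carries pyridin-4-yl in place of 4-hydroxyphenyl on a carbon with a double bond to nitrogen. For the measured compounds named here, no measured step exchanges the whole terminal aryl ring; the steps that bear on it are the three substituent exchanges on that same ring, every one of which stayed within the scatter. The exchange in compound 4 is larger than any of those, so the uncertainty is wider, but the measured series gives no ground for a step in either direction. In this assay no step beyond the scatter is therefore expected from compound 3 to compound 4.

Compound 4 is estimated at 750 nM, with a range from 300 nM to 1900 nM. The expected step is a 1.0-fold lower number from compound 3 to compound 4 (0.02 log units; within the scatter).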

Compound 4, half-maximal inhibitory concentration: 840 nM
Compound 4: the middle estimate sits 1.1-fold (0.05 log units) below what was measured; measured number inside the range.
By their numbers in this assay, from the lowest: compounds 2, 1, 3 and 4 (each within the scatter of the next).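

In this assay, exchanging the whole terminal aryl ring on the carbon with a double bond to nitrogen, rather than only a substituent on it, stays within the scatter against all three earlier compounds: a 1.1-fold higher number from compound 3 to compound 4 (0.03 log units; within the scatter), a 1.4-fold higher number from compound 2 to compound 4 (0.15 log units; within the scatter), and a 1.3-fold higher number from compound 1 to compound 4 (0.10 log units; within the scatter). The earlier compounds shown here varied only the substituent on a ring of carbon only, whereas compound 4 brings a hetero atom into the ring itself and has no substituent on it, and the four compounds still read as one level. The exchange of 4-hydroxyphenyl, with 1 hydrogen-bond donor, for pyridin-4-yl, with 0, likewise leaves no readable difference, and no measurement in hand bears on why this position gives so little response.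

Open, going by these compounds, is whether a carboxylic acid or an aminomethyl group on the terminal ring, or a saturated piperidine ring in place of that ring, would give a step beyond the scatter. Also open, on these data alone, is how much of this common level comes from the shared core, which is the same in all four compounds.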